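The source may report more compounds than this note shows. Statements on the series, on what has been measured and on what is new or still open speak of the compounds shown alone.

Compound 1, `N[C@@H](COP(=O)(O)OCCCOC(=O)CCc1ccccc1OCc1cccc(Cc2ccccc2)c1)C(=O)O`, in an assay on cells for agonist activity at probable G-protein coupled receptor 34 (Mus musculus), with a stated time of 1 h; a higher number here means a larger maximal response, a lower number a smaller maximal response: 14.5%
Compound 2, `N[C@@H](COP(=O)(O)OCCCOC(=O)CCc1ccccc1OCc1cccc(Oc2ccccc2Cl)c1)C(=O)O`, in this assay: 19.8%

Within the data shown here, compound 2 holds the higher of the two numbers so far, but the step of a number 5.3 percentage points higher from compound 1 to compound 2 (within the scatter) lies within the scatter, so the two compounds cannot be ranked against each other. Compound 3, `N[C@@H](COP(=O)(O)OCCCOC(=O)CCc1ccccc1OCc1cccc(Oc2ccc(Cl)cc2)c1)C(=O)O`, has not yet been measured. It differs from compound 2 by 4-chlorophenyl in place of 2-chlorophenyl on an oxygen on an aromatic ring. Among the measured compounds shown here, no measured step bears directly on this change; the only step known, a number 5.3 percentage points higher from compound 1 to compound 2 (within the scatter), exchanges a benzyl for a 2-chlorophenoxy and stays within the scatter. The outcome for compound 3 is therefore expected to be a step of no size beyond the scatter in this assay, in neither direction. Compound 3 is estimated at 20%, with a range from 8% to 35%. This estimate means an expected step of a number 0.2 percentage points higher from compound 2 to compound 3 (within the scatter), which would remain within the scatter.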

Compound 3, largest response reached (Emax), in percent of the reference or control that the assay uses: 17.8%
The estimate for compound 3 lay 2.2 percentage points above the measured number; the range from low to high includes it.
By their numbers in this assay, from the lowest: compounds 1, 3 and 2 (each within the scatter of the next).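

In this assay, 4-chlorophenyl in place of 2-chlorophenyl on an oxygen on an aromatic ring gives a number 2 percentage points lower from compound 2 to compound 3 (within the scatter), so the two chlorophenyl groups cannot be told apart at this position. The exchange of benzyl for 4-chlorophenoxy on an aromatic carbon gives a number 3.3 percentage points higher from compound 1 to compound 3 (within the scatter), which means that neither chlorophenoxy group can be separated from benzyl and all three compounds remain within the scatter of one another. No evidence is available that would explain these results.

As far as these compounds go, it remains open whether a plain phenoxy group, without the chlorine, would differ from these compounds in this assay. From the compounds shown here alone, it is also open whether an amine or a carboxylic acid in place of the chlorine would produce a step beyond the scatter.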